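Series notes: changes at one aromatic carbon

This account rests on a few compounds, and the source may have more. Where it says the series, first, only, none or still open, it means among the compounds named here.

Measured so far, in an assay on isolated protein (strain Sprague-Dawley) for inhibition of Amine oxidase [flavin-containing] A (Rattus norvegicus), read by spectrophotometry, with a stated time of 5 min, tested at 10 uM; on this read-out higher numbers stand for more inhibition at the one concentration tested (going by the name of the read-out) and lower numbers for less inhibition:
compound 1 `CCOc1cc(=O)oc2cc(OCc3cccc(Cl)c3)ccc12` gives 2%
compound 2 `CNC(=O)COc1cc(=O)oc2cc(OCc3cccc(Cl)c3)ccc12` gives 11%
compound 3 `O=c1cc(CCl)c2ccc(OCc3cccc(Cl)c3)cc2o1` gives 21%

Compound 3 stands highest of the three, with compound 2 nearest and compound 1 furthest, as a number 10 percentage points higher from compound 2 to compound 3 (within the scatter) and a number 19 percentage points higher from compound 1 to compound 3 (beyond the scatter) show. Compound 4 `O=C(O)c1cc(=O)oc2cc(OCc3cccc(Cl)c3)ccc12` differs from compound 3 in one place: carboxy in place of chloromethyl on an aromatic carbon. Among the compounds with values here, the steps that bear on it are those at the same aromatic carbon, a number 19 percentage points higher from compound 1 to compound 3 (beyond the scatter) and a number 10 percentage points higher from compound 2 to compound 3 (within the scatter), both into chloromethyl; no step out of chloromethyl or into carboxy is measured. Since each replacement at this carbon moved the number modestly or within scatter, a return toward the lower end of the range seen so far is expected for compound 4, a number 11 percentage points lower from compound 3 to compound 4 (beyond the scatter). Compound 4 is estimated at 10%, between 0% and 25%.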

Compound 4, a percentage reported as inhibition, at one concentration (the size of the read-out at that concentration, not a potency): 0%
The estimate for compound 4 lay 10 percentage points above the measured number; the range from low to high includes it.
By their numbers in this assay, from the lowest: compounds 4, 1, 2 and 3 (each within the scatter of the next, the first and the last beyond it).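

At this aromatic carbon, opposite the ring oxygen, carboxy gives the first step out of chloromethyl in this assay (a number 21 percentage points lower from compound 3 to compound 4 (beyond the scatter)), and the number falls beyond the scatter. Carboxy also stands beyond the scatter against (methylcarbamoyl)methoxy (a number 11 percentage points lower from compound 2 to compound 4 (beyond the scatter)), but it cannot be told apart from ethoxy (a number 2 percentage points lower from compound 1 to compound 4 (within the scatter)). Of the four groups, only chloromethyl stands beyond the scatter of both ethoxy and carboxy.

Nothing available explains these differences. On these data alone, whether an aminomethyl group or a longer chloroalkyl chain at this carbon would exceed chloromethyl stays open.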